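Methyl to phenyl: a step expected to stay small

The source may hold more compounds than are shown below. What is called first, only, known or untested is meant among the compounds shown, and "the series" means these compounds.

In a functional assay on MOLT-4 cells (Homo sapiens) for antiproliferative activity, read by MTT assay, with a stated time of 48 h (on this read-out higher numbers stand for weaker inhibition and lower numbers for stronger inhibition), compound 2 `CNc1nc(Nc2cnn(CCCCCCC(=O)NO)c2)ncc1Cl` gives 110 nM and stands within the scatter of its two measured relatives (compound 1 `O=C(CCCCCCn1cc(Nc2ncc(Cl)c(Nc3cccc(Cl)c3)n2)cn1)NO` at 130 nM and compound 3 `O=C(CCCCCn1cc(Nc2ncc(Cl)c(Nc3ccc(F)cc3)n2)cn1)NO` at 120 nM). Compound 4 `O=C(CCCCCCn1cc(Nc2ncc(Cl)c(Nc3ccccc3)n2)cn1)NO` carries phenyl in place of methyl on a nitrogen on an aromatic ring, a change counted as phenyl in place of methyl on a nitrogen on an aromatic ring against compound 2. For the measured compounds named here, one measured step bears on it: a 1.2-fold lower number from compound 1 to compound 2 (0.07 log units; within the scatter) with methyl in place of 3-chlorophenyl on that nitrogen, and it stayed within the scatter. No step beyond the scatter is therefore expected in this assay for this change. The estimated step is a 1.1-fold higher number from compound 2 to compound 4 (0.04 log units; within the scatter) in size. Compound 4 is expected to give 120 nM (range 60 nM to 250 nM).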

Compound 4, half-maximal inhibitory concentration: 160 nM
Compound 4: the middle estimate sits 1.3-fold (0.12 log units) below what was measured; the measured number falls inside the stated range.
By their numbers in this assay, from the lowest: compounds 2, 3, 1 and 4 (each within the scatter of the next).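

In this assay, phenyl in place of methyl on a nitrogen on an aromatic ring now has its own direct reading: a 1.5-fold higher number from compound 2 to compound 4 (0.16 log units; within the scatter). Hydrogen in place of chloro on an aromatic carbon of that phenyl gives a 1.2-fold higher number from compound 1 to compound 4 (0.09 log units; within the scatter). Methyl, phenyl and 3-chlorophenyl on this nitrogen therefore cannot be told apart in this assay.

No outside measurement bears on why these steps stay so small. As far as these compounds go, whether a benzyl group or a chain ending in an amine on this nitrogen would also stay within the scatter remains open.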